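Swapping the Aryl Group on the Amine Nitrogen

The source may report more compounds than this note shows. Statements on the series, on what has been measured and on what is new or still open speak of the compounds shown alone.

Compound 1, `COc1cccc(NC2=CC(=O)c3c(nc4n3[C@H]3OC[C@@H](O)[C@H]3OC4)C2=O)c1`, gives in a functional assay on HeLa cells (Homo sapiens) for inhibition, read by sulforhodamine B assay (a higher number here means a weaker inhibitor, a lower number a stronger inhibitor), a limit rather than a number: > 8000 nM.
Compound 2, `CCCc1ccc(NC2=CC(=O)c3c(nc4n3[C@H]3OC[C@@H](O)[C@H]3OC4)C2=O)cc1`, gives in this assay 6030 nM.
Compound 3, `O=C1C(Nc2ccccc2F)=CC(=O)c2c1nc1n2[C@H]2OC[C@@H](O)[C@H]2OC1`, gives in this assay 9820 nM.

All three share one core and differ only in the aryl group attached to an amine nitrogen. Among them, compound 2 and compound 3 are the two with a real number, and they sit within the scatter of each other, as a 1.6-fold higher number from compound 2 to compound 3 (0.21 log units; within the scatter) shows; neither can be called the stronger inhibitor. The value of compound 1 is a limit: the limit of > 8000 nM in this assay, at which 1 of the 3 values shown sits. Starting from it, a step that the limit leaves unreadable from compound 1 to compound 3, and an at least 1.3-fold lower number from compound 1 to compound 2 (0.12 log units; that floor lies within the scatter) only sets a floor that itself lies within the scatter.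

Compound 4, `O=C1C(Nc2ccc(C(F)(F)F)cc2)=CC(=O)c2c1nc1n2[C@H]2OC[C@@H](O)[C@H]2OC1`, brings in yet another aryl group: 4-(trifluoromethyl)phenyl in place of 2-fluorophenyl on an amine nitrogen. Every measured step here is the same kind of exchange of one aryl group for another on that nitrogen, and none of them moved the number beyond the scatter. The expectation is therefore a similarly small step, a 1.1-fold lower number from compound 3 to compound 4 (0.04 log units; within the scatter), with no clear direction. Compound 4 is thus estimated to give about 9000 nM in this assay, with a likely range from 4000 nM to 20000 nM.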

Compound 4, half-maximal inhibitory concentration: 8920 nM
The estimate for compound 4 lay 1.0-fold (0.00 log units) above the measured number; the range from low to high includes it.
By their numbers in this assay, from the lowest: compounds 2, 4 and 3 (each within the scatter of the next).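

Putting 4-(trifluoromethyl)phenyl in place of 2-fluorophenyl on the amine nitrogen makes the aryl group larger by heavy-atom count and changes its fluorine content, yet the result is a 1.1-fold lower number from compound 3 to compound 4 (0.04 log units; within the scatter). Compound 2 and compound 4 now also form a pair that differs only in trifluoromethyl in place of propyl on an aromatic carbon, and that exchange gives a 1.5-fold higher number from compound 2 to compound 4 (0.17 log units; within the scatter), so these two groups cannot be told apart in this assay. Compound 1 carries a limit rather than a number, and the step from it to compound 4 cannot be read: the limit of > 8000 nM in this assay, at which 1 of the 4 values shown sits.

Every aryl group shown on this nitrogen is a substituted phenyl ring, and the three real numbers all lie within the scatter of their neighbours, so it remains open whether any group at this position can move the number beyond the scatter. A pyridine ring, a phenyl ring bearing a carboxylic acid or an amine, or a plain alkyl chain in place of the aryl group would test this, and the four compounds shown cannot say how any of these would behave.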